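Oxadiazole in place of isobutoxy on an acid-tailed amide

This account rests on a few compounds, and the source may have more. Where it says the series, first, only, none or still open, it means among the compounds named here.

Compound 3 `CC(C)COc1cccc(-c2ccc(C(=O)N(Cc3cccc(OCCCCCC(=O)O)c3)C(C)C)cc2)c1` was tested in an ADME assay on Raji cells (Homo sapiens) for cytotoxicity, read by CellTiter-Glo and resazurin assay, with a stated time of 72 h; a lower number here means that less compound is needed, a higher number that more compound is needed for the effect. In this assay compound 3 gives > 26000 nM, which is a limit of the assay and not a number. Compound 1 `CC(C)N(Cc1cccc(OCCCCCC(=O)O)c1)C(=O)c1ccc(-c2ccncc2)cc1` gives > 26000 nM, likewise a limit. Compound 2 `CC(=O)c1cccc(-c2ccc(C(=O)N(Cc3cccc(OCCCCCC(=O)O)c3)C(C)C)cc2)c1` gives > 26000 nM, again a limit. All three sit at the same point, since (the limit of > 26000 nM in this assay, at which 3 of the 3 values shown sit). The steps among them are therefore not readable in size: a step that the two limits leave unreadable from compound 1 to compound 2, a step that the two limits leave unreadable from compound 1 to compound 3 and a step that the two limits leave unreadable from compound 2 to compound 3.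

Compound 4 `Cc1nnc(-c2cccc(-c3ccc(C(=O)N(Cc4cccc(OCCCCCC(=O)O)c4)C(C)C)cc3)c2)o1` differs from compound 3 in one place: 5-methyl-1,3,4-oxadiazol-2-yl in place of isobutoxy on an aromatic carbon. The step from compound 2 to compound 3 is the nearest comparison, an exchange at the same aromatic carbon, but it gives no readable size because of the limit of > 26000 nM in this assay, at which 3 of the 3 values shown sit. For the measured compounds named here, no measured step offers a direction beyond the scatter.

Compound 4 is therefore expected to remain at the limit, with an estimated step that the limit leaves unreadable from compound 3 to compound 4. The estimate for compound 4 is 30000 nM, expected to fall between 10000 nM and 100000 nM.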

Compound 4, half-maximal effective concentration: > 26000 nM
Compound 4 ended at the assay's limit; the forecaster's own chance of this, stated with the estimate: 85%; the middle value does not contradict the limit.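

Compound 4 joins compound 1, compound 2 and compound 3 at a limit of the assay, so no step among these four compounds can be read in size: the limit of > 26000 nM in this assay, at which 4 of the 4 values shown sit.

The compounds shown leave open how far any of them lies from that limit in this assay.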